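The compounds below may be only part of what the source reports. "The series", "measured", "known", "first", "only" and "open" are said of these compounds alone.

Measured so far in a functional assay on MCF7 cells (Homo sapiens) for inhibition, read by sulforhodamine B assay; a lower number here means a stronger inhibitor, a higher number a weaker inhibitor:
- compound 1 `O=C1C(Nc2ccc(I)cc2)=CC(=O)c2c1nc1n2[C@H]2OC[C@@H](O)[C@H]2OC1` gives 3890 nM
- compound 2 `O=C1C=C(NCc2ccccc2)C(=O)c2c1nc1n2[C@H]2OC[C@@H](O)[C@H]2OC1` gives only a limit, > 8000 nM
- compound 3 `O=C1C=C(NC2CCCC2)C(=O)c2c1nc1n2[C@H]2OC[C@@H](O)[C@H]2OC1` gives only a limit, > 16000 nM

Among the measured compounds shown here, compound 1 holds the only read number in this assay. The value of compound 2 is a limit of this assay and not a number. The value of compound 3 is likewise a limit of this assay and not a number. For the measured compounds named here, the one step between measured compounds, a step that the two limits leave unreadable from compound 2 to compound 3, is cyclopentyl in place of benzyl on an amine nitrogen; it runs between the two limits the limit of > 8000 nM in this assay, at which 1 of the 3 values shown sits, and the limit of > 16000 nM in this assay, at which 1 of the 3 values shown sits, and so gives no readable size.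

Compound 4 `O=C1C(Nc2ccc(C(F)(F)F)cc2)=CC(=O)c2c1nc1n2[C@H]2OC[C@@H](O)[C@H]2OC1` differs from compound 1 by trifluoromethyl in place of iodo on an aromatic carbon, on an aromatic carbon of a six-membered aromatic ring of carbon only, with 4-iodophenyl becoming 4-(trifluoromethyl)phenyl. Going by the values given here, no measured step touches this ring or this position; the only measured step concerns the amine substituent and is itself unreadable. There is therefore nothing in the numbers to expect a step beyond the scatter in this assay, in either direction, for compound 4.

The estimate for compound 4 is thus 4500 nM, with a range of 1500 nM to 14000 nM. The expected step of a 1.2-fold higher number from compound 1 to compound 4 (0.06 log units; within the scatter) is taken as lying within the scatter of this assay.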

Compound 4, half-maximal inhibitory concentration: > 4000 nM
Compound 4: only a limit was reported; the forecaster's own chance of this, stated with the estimate: 30%; the middle value lies beyond the limit too.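

In this assay compound 4 gives > 4000 nM, a limit of the assay and not a number. On this aromatic carbon, para to a large group, trifluoromethyl in place of iodo gives an at least 1.0-fold higher number from compound 1 to compound 4 (0.01 log units; that floor lies within the scatter); the result therefore fits both a change within the scatter and a much weaker compound, with no ceiling on the size of the step. Among the compounds shown here, this is the first result for a change at this position, where the earlier compounds offered only the single read number of compound 1 and no comparison, but it shows only that replacing iodo with trifluoromethyl did not leave a read number in this assay.

Neither the true value of compound 4 nor the effect of the amine substituent is settled, and the step from benzyl to cyclopentyl cannot be read. Also open, as far as these compounds go, is how other groups on this aromatic carbon, such as a methoxy group, an amine or a carboxylic acid, would compare with iodo on the core of compound 1.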